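Notes on an acyl swap in a dinitrophenyl conjugate series

A few compounds are considered here, and "the series" means these few. Any claim that something is new, unique, unknown or untested is made for them only; others in the source may bear on it.

Measured so far:
compound 1 `CCCCOC(=O)CNC(=O)[C@H](CSc1ccc([N+](=O)[O-])cc1[N+](=O)[O-])NC(=O)CC[C@H](NC(=O)OC(C)(C)C)C(=O)OCCCC`: 70.4 uM
compound 2 `CCCCCCCCCCCCCC(=O)N[C@@H](CCC(=O)N[C@@H](CSc1ccc([N+](=O)[O-])cc1[N+](=O)[O-])C(=O)NCC(=O)OCCCC)C(=O)OCCCC`: > 300 uM
compound 3 `CCCCOC(=O)CNC(=O)[C@H](CSc1ccc([N+](=O)[O-])cc1[N+](=O)[O-])NC(=O)CC[C@H](NC(=O)CCC(C)C)C(=O)OCCCC`: 84 uM

All three were read in a toxicity assay on KB cells (Homo sapiens) for cytotoxicity, read by fluorescence, with a stated time of 3 days; a higher number here means that more compound is needed for the effect, a lower number that less compound is needed. In this assay compound 1 gives 70.4 uM and compound 3 gives 84 uM; the step of a 1.2-fold higher number from compound 1 to compound 3 (0.08 log units; within the scatter). For compound 2 this assay reports only a limit, > 300 uM. The step of an at least 3.5-fold lower number from compound 2 to compound 3 (0.55 log units; beyond the scatter), and its size is bounded only by the limit of > 300 uM in this assay, at which 1 of the 3 values shown sits. Of the two numbers shown, compound 3 holds the higher, with compound 1 nearest and within the scatter of it.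

Compound 4 `CCCCOC(=O)CNC(=O)[C@H](CSc1ccc([N+](=O)[O-])cc1[N+](=O)[O-])NC(=O)CC[C@H](NC(=O)/C=C/c1ccccc1)C(=O)OCCCC` differs from compound 3 by 2-phenylethenyl in place of isopentyl on a carbonyl carbon. The step from compound 1 to compound 3 changed the group on the same carbonyl carbon and stayed within the scatter; the step from compound 2 to compound 3 concerned a saturated chain carbon elsewhere and ran beyond it, ending at a limit. Two precedents, one at the matching position and flat, give little ground for a move. Compound 4 is therefore expected to sit near compound 3, the step of a 1.1-fold lower number from compound 3 to compound 4 (0.02 log units; within the scatter) expected to lie within the scatter. The estimate for compound 4 is 80 uM, between 35 uM and 200 uM.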

Compound 4, concentration for half-maximal effect: 34.4 uM
Estimate against measurement, compound 4: 2.3-fold (0.37 log units) above; the measured number lies below the stated range.
By their numbers in this assay, from the lowest: compound 4; then compounds 1 and 3 (each within the scatter of the next). At a limit, above all of these: compound 2.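

In this assay, the carbonyl carbon whose other neighbour is the amide-type nitrogen now shows that it can respond to the group it carries: the earlier change there, a 1.2-fold higher number from compound 1 to compound 3 (0.08 log units; within the scatter), stayed within the scatter, whereas the new steps, a 2.4-fold lower number from compound 3 to compound 4 (0.39 log units; beyond the scatter) and a 2.0-fold lower number from compound 1 to compound 4 (0.31 log units; beyond the scatter), both pass beyond it. The two new steps run in the same direction and are modest, so 2-phenylethenyl separates from both isopentyl and tert-butoxy, while those two remain within the scatter of each other. The one supporting observation available concerns only the limit of compound 2, so nothing measured here accounts for the shift at this position.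

The compounds shown do not separate the contributions of the six-membered aromatic ring and the double bond that enter together with 2-phenylethenyl, a question that a saturated 2-phenylethyl group or a phenyl group directly on the carbonyl carbon would address. Also open, going by these compounds, is whether the lower number would hold with an amine or a carboxylic acid on that ring.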